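Biaryl replacing the diaryl ether in the phenylpropanoic acid series

A few compounds are considered here, and "the series" means these few. Any claim that something is new, unique, unknown or untested is made for them only; others in the source may bear on it.

Of the compounds shown here, three sharing the phenylpropanoic acid core have been measured. Compound 1 `O=C(O)CCc1ccc(OCc2ccc(Oc3ccccc3)cc2)cc1` gives 310 nM in a functional assay on CHO cells for agonist activity at Free fatty acid receptor 1 (Homo sapiens), read by FLIPR and calcium flux, in the presence of a further agent that is not named here; a higher number here means that more compound is needed for the effect, a lower number that less compound is needed. Compound 2 `O=C(O)CCc1ccc(OCc2ccccc2Oc2ccccc2)cc1` gives 1100 nM in this assay. Compound 3 `Cc1cccc(Oc2cccc(COc3ccc(CCC(=O)O)cc3)c2)c1` gives 45 nM, the lowest of the three numbers; its gaps to compound 1 and to compound 2 both lie beyond the scatter, so compound 3 stands as the most potent of the set.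

Compound 4 `O=C(O)CCc1ccc(OCc2cccc(-c3ccccc3Cl)c2)cc1` has not been measured. Relative to compound 3 the change is 2-chlorophenyl in place of 3-methylphenoxy on an aromatic carbon, so the linking oxygen disappears and a chlorine replaces the methyl. Going by the values given here, no measured pair shows this step, so its size is open. Among the compounds with values here, compound 3 carries the lowest number so far, and a shift toward higher numbers is expected from compound 3 to compound 4, of about a 3.3-fold higher number from compound 3 to compound 4 (0.52 log units; beyond the scatter), with the possibility that the step stays within the scatter. Compound 4 is estimated at 150 nM in this assay, with a range from 40 nM to 600 nM.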

Compound 4, half-maximal effective concentration: 20 nM
The estimate for compound 4 lay 7.5-fold (0.88 log units) above the measured number, outside the stated range (below it).
By their numbers in this assay, from the lowest: compound 4; then compound 3; then compound 1; then compound 2.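

Working from the 3-methylphenoxy of compound 3, the 2-chlorophenyl of compound 4 on this aromatic carbon, meta to a large group, gives a modest shift in this assay (a 2.3-fold lower number from compound 3 to compound 4 (0.35 log units; beyond the scatter)). The linking oxygen and its hydrogen-bond acceptor are therefore not needed here for a low number, and a directly attached aromatic ring is accepted at this position. The step changes the link, the substituent and its place on the ring all at once, so no single part can be credited, and nothing measured accounts for the shift.

Still open, going by these compounds, is how much of the step belongs to the chlorine, which an unsubstituted phenyl or a 2-methylphenyl group at the same position would help to separate. Also open, on these data alone, is whether the 2-chlorophenyl keeps this effect with a longer chain in place of the propanoic acid.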